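Turning One Stereocentre in Compound 2

The compounds below may be only part of what the source reports. "The series", "measured", "known", "first", "only" and "open" are said of these compounds alone.

- compound 1 (`CC(C)(C)Sc1c(CC(C)(C)C(=O)O)n(Cc2ccc(Cl)cc2)c2ccc(OCc3ccc4cc(F)c(F)cc4n3)cc12`) gives 7 nM
- compound 2 (`C[C@@H](COc1ccc2c(c1)c(SC(C)(C)C)c(CC(C)(C)C(=O)O)n2Cc1ccc(Cl)cc1)c1ccccn1`) gives 2 nM
- compound 3 (`C[C@H](COc1ccc2c(c1)c(SC(C)(C)C)c(CC(C)(C)C(=O)O)n2Cc1ccc(Cl)cc1)c1ccccn1`) has not yet been measured

These numbers come from a functional assay for inhibition, with Homo sapiens as the target (on this read-out higher numbers stand for weaker inhibition and lower numbers for stronger inhibition), and compound 2 holds the lower of the two (2 nM), making it the stronger inhibitor so far. The change to compound 3 is small on paper (the two compounds have the same atoms and bonds and differ only in configuration as drawn: 1 of 1 stereo elements differ; a stereocentre at a saturated chain carbon is drawn R in compound 2 and S in compound 3): a stereocentre at a saturated chain carbon is drawn R in compound 2 and S in compound 3.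

Within the data shown here, only one measured step exists, a 3.5-fold lower number from compound 1 to compound 2 (0.54 log units; beyond the scatter), and it was modest. That step exchanges a whole group, so it bears only loosely on this question. Among the measured compounds shown here, no pair differing only in configuration has been measured here, which leaves the size of the change open. With compound 2 at the low end (2 nM), a modest rise is expected rather than a further drop. The estimated change is a 2.5-fold higher number from compound 2 to compound 3 (0.40 log units; beyond the scatter). Compound 3 is expected at 5 nM, within an estimated range of 1.5 nM to 20 nM.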

Compound 3, half-maximal inhibitory concentration: 3 nM
Beside the measured number, compound 3's estimate is 1.7-fold (0.22 log units) above it; measured number inside the range.
By their numbers in this assay, from the lowest: compounds 2 and 3 (each within the scatter of the next); then compound 1.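

In this assay, turning this one stereocentre gives a 1.5-fold higher number from compound 2 to compound 3 (0.18 log units; within the scatter), so on this read-out the R and S forms cannot be told apart, and the position shows no clear preference for either configuration. This is the first comparison here that isolates the stereocentre, since the earlier step exchanged a whole group, and this time nothing else can account for the result: the fact that compounds 2 and 3 differ only in the configuration as drawn

The exchange of groups also holds up with the opposite configuration, as the group of 8 heavy atoms in place of the group of 12 heavy atoms gives a 2.3-fold lower number from compound 1 to compound 3 (0.37 log units; beyond the scatter), so the lower number seen earlier with compound 2 is not tied to the R form alone.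

The compounds shown carry only one six-membered aromatic ring with 1 hetero atom on this saturated chain carbon, so it remains open whether configuration would still matter so little with an amine or a longer chain in its place. Also open, from the compounds shown here alone, is whether the two forms would stay this close on any read-out other than this assay.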